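Fluorophenyl for Methylsulfonylphenyl in a Benzopyran Series

The compounds below may be only part of what the source reports. "The series", "measured", "known", "first", "only" and "open" are said of these compounds alone.

Compound 1 `CC1=C(c2ccc(S(C)(=O)=O)cc2)C(c2ccc(OC[C@H](C)N3CC[C@@H](C)C3)cc2)Oc2ccc(O)cc21` gives the higher of the two numbers in a functional assay on MCF7 cells (Homo sapiens) for antiproliferative activity, read by CellTiter-Glo, with a stated time of 5 days (a lower number here means a stronger inhibitor, a higher number a weaker inhibitor), with compound 1 at 27 nM, while compound 2 `CC1=C(c2cccc(O)c2)C(c2ccc(OC[C@H](C)N3CCCC3)cc2)Oc2ccc(O)cc21` gives the far lower number, at 0.2 nM. Compound 3 `CC1=C(c2cccc(F)c2)C(c2ccc(OC[C@H](C)N3CC[C@@H](C)C3)cc2)Oc2ccc(O)cc21` departs from compound 1 by a single change: 3-fluorophenyl in place of 4-(methylsulfonyl)phenyl on a double-bonded ring carbon. For the measured compounds named here, no measured pair isolates this change, so its effect can only be estimated. The author expects a downward step from compound 1 to compound 3 of roughly a 9.0-fold lower number from compound 1 to compound 3 (0.95 log units; beyond the scatter), well beyond the scatter. Compound 3 is accordingly estimated at 3 nM, with a plausible range from 0.5 nM to 15 nM.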

Compound 3, half-maximal inhibitory concentration: 1 nM
For compound 3 the middle estimate is 3.0-fold (0.48 log units) above the measured one; low and high end bracket the measured number.
By their numbers in this assay, from the lowest: compound 2; then compound 3; then compound 1.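

With the rest of the molecule held the same, 3-fluorophenyl in place of 4-(methylsulfonyl)phenyl on this double-bonded ring carbon gives a 27-fold lower number from compound 1 to compound 3 (1.43 log units; beyond the scatter) in this assay. For the compounds shown here, this is the first pair to isolate this position, and it shows that the choice of aryl group there strongly moves the antiproliferative number. Nothing given here accounts for the size of this step.

On these data alone, whether the step follows the loss of the methylsulfonyl group or the arrival of the fluorine stays open, since the pair changes both at once. A plain phenyl on this carbon would bear on that question.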